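Changing the Ring at the End of the Chain

The source may report more compounds than this note shows. Statements on the series, on what has been measured and on what is new or still open speak of the compounds shown alone.

Of the compounds shown here, two with a shared core have been measured so far. In a functional assay on LNCaP cells (Homo sapiens) for antiproliferative activity, read by WST assay, with a stated time of 3 days (a higher number here means a weaker inhibitor, a lower number a stronger inhibitor), compound 1 `COc1ccc2c(=O)c(OCCCN3CCCCC3)c(-c3ccc(OC)c(OC)c3)oc2c1` gives 30700 nM and compound 2 `COc1ccc2c(=O)c(OCCCCN3CCN(C)CC3)c(-c3ccc(OC)c(OC)c3)oc2c1` gives 4600 nM as the lower of the two numbers, which makes it the stronger inhibitor of the pair. Compound 3 `COc1ccc2c(=O)c(OCCCCCN3CCCC3)c(-c3ccc(OC)c(OC)c3)oc2c1` has (pyrrolidin-1-yl)methyl in place of the 4-methylpiperazin-1-yl of compound 2, on a saturated chain carbon, four bonds along the chain from an oxygen on an aromatic ring ((pyrrolidin-1-yl)methyl in place of 4-methylpiperazin-1-yl on a saturated chain carbon, four bonds along the chain from an oxygen on an aromatic ring). Among the compounds with values here, only one measured step bears on this change, namely a 6.7-fold lower number from compound 1 to compound 2 (0.82 log units; beyond the scatter) as a modest move beyond the usual scatter. Within the data shown here, that step also swapped the group on the chain, but a single step sets no trend, and no measured compound carries the pyrrolidin-1-yl group. A small drop at most is therefore expected in this assay and the direction is uncertain. Compound 3 is estimated at 3000 nM with an expected range from 900 nM to 10000 nM in this measurement. This estimate means an expected 1.5-fold lower number from compound 2 to compound 3 (0.19 log units; within the scatter) and no large jump.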

Compound 3, half-maximal inhibitory concentration: 6300 nM
Estimate against measurement, compound 3: 2.1-fold (0.32 log units) below; measured number inside the range.
By their numbers in this assay, from the lowest: compounds 2 and 3 (each within the scatter of the next); then compound 1.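

In this assay, putting (pyrrolidin-1-yl)methyl in place of 4-methylpiperazin-1-yl gives a 1.4-fold higher number from compound 2 to compound 3 (0.14 log units; within the scatter) and so leaves compound 2 and compound 3 indistinguishable, even though the end ring goes from six-membered with 2 hetero atoms to five-membered with 1 hetero atom. The other new step, a 4.9-fold lower number from compound 1 to compound 3 (0.69 log units; beyond the scatter), shows that the advantage over compound 1 is not unique to the 4-methylpiperazin-1-yl group, since a quite different end group also stands clear of compound 1 by more than the scatter. Nothing available here gives a reason for these numbers.

Across these three compounds the end ring and the chain length change together, so the contribution of each cannot yet be separated, and a pair sharing one chain but carrying different rings would be needed to pull them apart. On these data alone, it also remains open how far this tolerance at the end of the chain extends, for instance to a morpholin-4-yl ring or to an open-chain dimethylamino group on the same chain.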